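This account rests on a few compounds, and the source may have more. Where it says the series, first, only, none or still open, it means among the compounds named here.

Measured so far in a functional assay on TK-10 cells (Homo sapiens) for inhibition, read by sulforhodamine B assay, with a stated time of 48 h; a lower number here means a stronger inhibitor of growth, a higher number a weaker inhibitor of growth:
compound 1 `CN1CCN(CCCOc2cccc3nc(Nc4ccc(F)c(F)c4)ccc23)CC1` gives 2630 nM
compound 2 `CN1CCN(CCCOc2cccc3nc(Nc4cc(Cl)cc(Cl)c4)ccc23)CC1` gives 1740 nM

Of the two numbers shown, compound 2 has the smaller, with compound 1 its only neighbour; the step of a 1.5-fold lower number from compound 1 to compound 2 (0.18 log units; within the scatter) is within the scatter, so no order between the two is claimed. Compound 3 `CN1CCN(CCCOc2cccc3nc(Nc4cccc(Cl)c4)ccc23)CC1` is not yet measured. It differs from compound 2 by hydrogen in place of chloro on an aromatic carbon. Within the data shown here, no measured step bears directly on this change: the single known step, a 1.5-fold lower number from compound 1 to compound 2 (0.18 log units; within the scatter), exchanges one whole halogenated phenyl for another and is itself within the scatter, and no measured pair removes a single chloro while the rest of the molecule stays fixed. Among the measured compounds shown here, with only that slight step to go on, the expectation for compound 3 is a change of a 1.4-fold higher number from compound 2 to compound 3 (0.16 log units; within the scatter), not beyond the scatter, in either direction. Compound 3 is therefore estimated at 2500 nM, with a range of 1000 nM to 6500 nM.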

Compound 3, concentration for 50% growth inhibition: 1670 nM
Compound 3: middle estimate off by 1.5-fold (0.18 log units), on the high side; the measured number falls inside the stated range.
By their numbers in this assay, from the lowest: compounds 3, 2 and 1 (each within the scatter of the next).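

In this assay, among these compounds, hydrogen in place of chloro on this aromatic carbon gives (a 1.0-fold lower number from compound 2 to compound 3 (0.02 log units; within the scatter)), so the 3,5-dichlorophenyl and 3-chlorophenyl compounds cannot be told apart at this carbon, and this is the first single-atom comparison. The 3-chlorophenyl group set against 3,4-difluorophenyl gives (a 1.6-fold lower number from compound 1 to compound 3 (0.20 log units; within the scatter)), so all three halogenated phenyl groups on this nitrogen now sit within the scatter of one another, and a single chloro serves as well as two in this read-out. Nothing available explains this flat result.

Still open, as far as these compounds go, is whether the remaining chloro matters at all, which a plain phenyl would test, and whether a methoxy group, a nitrile or a carboxylic acid at this carbon would separate from the halogens. Also open, from the compounds shown here alone, is whether a longer chain on the oxygen of the shared core would move the number beyond the scatter.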